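A few compounds are considered here, and "the series" means these few. Any claim that something is new, unique, unknown or untested is made for them only; others in the source may bear on it.

Measured compounds:
compound 1 `Cc1nc(NCc2ccco2)c2cnn(-c3ccccc3)c2n1`: > 100000 nM
compound 2 `Cc1nc(Nc2ccccc2)c2cnn(-c3ccccc3)c2n1`: > 100000 nM

In a functional assay on G-361 cells (Homo sapiens) for cytotoxicity, read by sulforhodamine B assay (a higher number here means a weaker inhibitor of growth, a lower number a stronger inhibitor of growth), compound 1 gives only a limit, > 100000 nM. Compound 2 likewise gives only a limit in this assay, > 100000 nM. The step that the two limits leave unreadable from compound 1 to compound 2 is unreadable, as both values sit at the limit of > 100000 nM in this assay, at which 2 of the 2 values shown sit. Compound 3 `Cc1nc(NCc2ccccc2)c2cnn(-c3ccccc3)c2n1` differs from compound 2 by benzyl in place of phenyl on a nitrogen on an aromatic ring. No measured step reads on this change; the only step shown is bounded at both ends. Compound 3 is expected to sit at the same limit, estimated at 150000 nM within 50000 nM to 500000 nM. The expected step, a step that the limit leaves unreadable from compound 2 to compound 3, is none beyond the scatter.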

Compound 3, concentration for total growth inhibition: > 100000 nM
Compound 3 was reported as a limit; the forecaster's own chance of this, stated with the estimate: 80%; the middle value lies beyond the limit too.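

In this assay, no step can be read among compound 1, compound 2 and compound 3, each reported only as a limit: the limit of > 100000 nM in this assay, at which 3 of the 3 values shown sit.

The compounds shown leave open which structural change, if any, would give a readable value.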